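The source may report more compounds than this note shows. Statements on the series, on what has been measured and on what is new or still open speak of the compounds shown alone.

Measured compounds in an assay on CHO cells for displacement of a labelled ligand from Substance-P receptor (Homo sapiens); on this read-out higher numbers stand for weaker inhibition and lower numbers for stronger inhibition:

- compound 1 `C[C@@H](O[C@@H]1CN(C=O)C[C@H]1c1ccc(F)cc1)c1cc(C(F)(F)F)cc(C(F)(F)F)c1`: 0.24 nM
- compound 2 `CCNC(=O)N1C[C@@H](O[C@H](C)c2cc(C(F)(F)F)cc(C(F)(F)F)c2)[C@H](c2ccc(F)cc2)C1`: 0.1 nM

Compound 2 stands at the lower of the two numbers in this assay. Going by the values given here, the single measured step between them, a 2.4-fold lower number from compound 1 to compound 2 (0.38 log units; beyond the scatter), is the only guide available: an ethylamino group in place of hydrogen on the carbonyl carbon moved the number down by a modest amount, beyond the scatter.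

Compound 3 `C[C@@H](O[C@@H]1CN(C2=CC(=O)N(C)C2)C[C@H]1c1ccc(F)cc1)c1cc(C(F)(F)F)cc(C(F)(F)F)c1` is the next member. Relative to compound 2 the change is a group of 7 heavy atoms (5 carbon, 1 nitrogen, 1 oxygen; one five-membered non-aromatic ring with 1 hetero atom) in place of a group of 5 heavy atoms (3 carbon, 1 nitrogen, 1 oxygen; no ring), on an amine nitrogen in a ring. Among the compounds with values here, no measured step bears directly on this kind of change; the step from compound 1 to compound 2 only shows that the group on the ring amine nitrogen can shift the number by a modest amount in this assay. The entering group is larger and cyclic and brings no hydrogen-bond donor, so the ethylcarbamoyl step cannot simply be carried over.

The expectation is therefore a step of about a 2.0-fold higher number from compound 2 to compound 3 (0.30 log units; within the scatter) from compound 2 to compound 3, which is within the usual scatter. Compound 3 is estimated at 0.2 nM in this assay, with a range from 0.05 nM to 0.8 nM.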

Compound 3, half-maximal inhibitory concentration: 0.12 nM
Estimate against measurement, compound 3: 1.7-fold (0.22 log units) above; low and high end bracket the measured number.
By their numbers in this assay, from the lowest: compounds 2, 3 and 1 (each within the scatter of the next, the first and the last beyond it).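

In this assay the amine nitrogen in the ring carries the new group, with its five-membered non-aromatic ring and 0 hydrogen-bond donors, in place of ethylcarbamoyl, and a 1.2-fold higher number from compound 2 to compound 3 (0.08 log units; within the scatter) does not separate the two compounds. Going by these compounds alone, the open chain and the hydrogen-bond donor of ethylcarbamoyl are therefore not required at this position for a number in this low range, at least when this particular ring enters, which the single earlier step could not show. Against the group on the same nitrogen in compound 1, a 2.0-fold lower number from compound 1 to compound 3 (0.30 log units; within the scatter) also stays inside the scatter, so compound 3 sits close to both earlier compounds even though these two differ from each other beyond it, and nothing at hand bears on why the number holds when the group changes this much.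

Still open, from the compounds shown here alone, is whether the same position keeps its number with a group of another kind, such as a primary amine, a carboxylic acid or a longer alkyl chain on the ring amine nitrogen. Also open, going by these compounds, is what the carbonyl and the N-methyl group of the entering ring each contribute, since only the whole ring has been compared with ethylcarbamoyl here.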